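Methoxy for methylsulfanyl: expected tolerance in the cytotoxicity assay

The source may report more compounds than this note shows. Statements on the series, on what has been measured and on what is new or still open speak of the compounds shown alone.

Compound 1 `COc1ccc(/C=N/NC(=O)COc2cccc3ccccc23)cc1O`: 100 ug/mL
Compound 2 `CSc1ccc(/C=N/NC(=O)COc2cccc3ccccc23)cc1`: >= 100 ug/mL

The read-out is an ADME assay on HEL cells (Homo sapiens) for cytotoxicity; a lower number here means that less compound is tolerated, a higher number that more compound is tolerated. Compound 1 `COc1ccc(/C=N/NC(=O)COc2cccc3ccccc23)cc1O` gives 100 ug/mL in this assay. Compound 2 `CSc1ccc(/C=N/NC(=O)COc2cccc3ccccc23)cc1` gives only a limit in this assay, >= 100 ug/mL, so its exact value is not known; it sits at the limit of >= 100 ug/mL in this assay, at which 1 of the 2 values shown sits. Compound 3 `COc1ccc(/C=N/NC(=O)COc2cccc3ccccc23)cc1` differs from compound 2 by methoxy in place of methylsulfanyl on an aromatic carbon. Among the measured compounds shown here, no measured step frames this change. The step of a number no higher from compound 2 to compound 3 (the limit leaves the size open) is expected to be none beyond the scatter, as the value of compound 1 in this assay also sits at the same level. Compound 3 is therefore estimated at 100 ug/mL, within 50 ug/mL to 200 ug/mL.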

Compound 3, minimum cytotoxic concentration: 20 ug/mL
Compound 3: the middle estimate sits 5.0-fold (0.70 log units) above what was measured; the measured number lies below the stated range.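

In this assay, the aromatic carbon para to a large group proves sensitive to this exchange: methoxy in place of methylsulfanyl gives an at least 5.0-fold lower number from compound 2 to compound 3 (0.69 log units; beyond the scatter). The hydroxy group of compound 1 matters as well, since hydrogen in place of hydroxy on an aromatic carbon gives a 5.0-fold lower number from compound 1 to compound 3 (0.70 log units; beyond the scatter). Compound 2 is known only as a limit, so the full size of its step stays open: the limit of >= 100 ug/mL in this assay, at which 1 of the 3 values shown sits.

On these data alone, whether an ethoxy group or an amine on that same carbon would track methylsulfanyl or methoxy remains open.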